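The source may hold more compounds than are shown below. What is called first, only, known or untested is meant among the compounds shown, and "the series" means these compounds.

Measured in a functional assay on Bel-7402 cells (Homo sapiens) for cytotoxicity, read by MTT assay, with a stated time of 72 h; on this read-out lower numbers stand for stronger inhibition and higher numbers for weaker inhibition:
compound 1 `C=C1C(=O)[C@@]23C(=O)OC[C@]4(C(=O)CCC(C)(C)[C@H]4C=O)[C@@H]2CC[C@@H]1[C@H]3O`: 5030 nM
compound 2 `C=C1C(=O)[C@@]23C(=O)OC[C@]4(C(=O)CCC(C)(C)[C@H]4C=O)[C@@H]2CC[C@@H]1[C@H]3OC(=O)c1ccc(F)cc1`: 3750 nM
compound 3 `C=C1C(=O)[C@@]23C(=O)OC[C@]4(C(=O)CCC(C)(C)[C@H]4C=O)[C@@H]2CC[C@@H]1[C@H]3OC(=O)c1ccccc1F`: 3950 nM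

Compound 1 gives the highest of the three numbers, yet both other compounds lie within the scatter of it. Compound 4 `C=C1C(=O)[C@@]23C(=O)OC[C@]4(C(=O)CCC(C)(C)[C@H]4C=O)[C@@H]2CC[C@@H]1[C@H]3OC(=O)c1ccc(Cl)cc1` differs from compound 1 by (4-chlorophenyl)carbonyl in place of hydrogen on an oxygen on a saturated carbon. Among the compounds with values here, two measured steps bear on this directly, the same substitution at the same place with (4-fluorophenyl)carbonyl and (2-fluorophenyl)carbonyl: a 1.3-fold lower number from compound 1 to compound 2 (0.13 log units; within the scatter) and a 1.3-fold lower number from compound 1 to compound 3 (0.10 log units; within the scatter); between those two products, a 1.1-fold higher number from compound 2 to compound 3 (0.02 log units; within the scatter). Nothing measured separates one ring substituent from another, so for compound 4 in this assay no step beyond the scatter is expected, a 1.3-fold lower number from compound 1 to compound 4 (0.12 log units; within the scatter). Compound 4 is therefore estimated at 3800 nM, with a range from 2000 nM to 7500 nM.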

Compound 4, half-maximal inhibitory concentration: 3840 nM
Beside the measured number, compound 4's estimate is 1.0-fold (0.00 log units) below it; low and high end bracket the measured number.
By their numbers in this assay, from the lowest: compounds 2, 4, 3 and 1 (each within the scatter of the next).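

In this assay, within the data shown here, chloro in place of fluoro on an aromatic carbon gives the first comparison of two halogens at the same ring place (a 1.0-fold higher number from compound 2 to compound 4 (0.01 log units; within the scatter)), and 4-chlorophenyl in place of 2-fluorophenyl also stays within the scatter (a 1.0-fold lower number from compound 3 to compound 4 (0.01 log units; within the scatter)). Against the free hydroxy, (4-chlorophenyl)carbonyl stays within it too (a 1.3-fold lower number from compound 1 to compound 4 (0.12 log units; within the scatter)), so the change of halogen adds no readable difference at this oxygen. No evidence bears on this result. Still open, as far as these compounds go, is whether a carbonyl group carrying an amine, a carboxylic acid or a longer chain in place of the halophenyl ring would move the number beyond the scatter.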